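Replacing the (4-chlorophenyl)amino group of compound 1

A few compounds are considered here, and "the series" means these few. Any claim that something is new, unique, unknown or untested is made for them only; others in the source may bear on it.

In a functional assay (strain AB) with Danio rerio as the target, read by microscopy, with a stated time of 1 h (a lower number here means that less compound is needed, a higher number that more compound is needed for the effect), compound 1 (`CCN1CCc2c(sc(NC(=O)Nc3ccc(Cl)cc3)c2C(N)=O)C1`) gives 3120 nM. Compound 3 (`CCN1CCc2c(sc(NC(=O)Nc3ccc(C(F)(F)F)cc3)c2C(N)=O)C1`) gives 2910 nM, within the scatter of compound 1, while compound 2 (`CC(C)N1CCc2c(sc(NC(=O)Nc3ccc(Cl)cc3)c2C(N)=O)C1`) gives 1490 nM. Compound 4 (`CCN1CCc2c(sc(NC(=O)[C@@H]3CCCN3)c2C(N)=O)C1`) differs far more from compound 1: pyrrolidin-2-yl in place of (4-chlorophenyl)amino on a carbonyl carbon. Here pyrrolidin-2-yl takes the place of (4-chlorophenyl)amino on a carbonyl carbon. For the measured compounds named here, only one measured step touches the leaving group, a 1.1-fold lower number from compound 1 to compound 3 (0.03 log units; within the scatter), and that change keeps the aromatic ring. The other, a 2.1-fold lower number from compound 1 to compound 2 (0.32 log units; beyond the scatter), concerns a different group. Going by the values given here, no measured step shows a swap of this kind, so a shift towards a higher number in this assay is only a cautious expectation. The expected change is a 2.6-fold higher number from compound 1 to compound 4 (0.41 log units; beyond the scatter). For compound 4 the estimated value is 8000 nM, with an expected range of 2000 nM to 35000 nM.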

Compound 4, half-maximal effective concentration: > 25000 nM
Compound 4 gave a limit, no number (the forecaster's own chance of this, stated with the estimate: 25%); middle value at least 3.1-fold (0.49 log units) from the limit.
By their numbers in this assay, from the lowest: compounds 2, 3 and 1 (each within the scatter of the next, the first and the last beyond it). At a limit, above all of these: compound 4.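

For the compounds shown here, until now, every step had kept the aromatic ring of the (4-chlorophenyl)amino group; this is the first to remove that group from the carbonyl carbon. In this assay compound 4 reaches only a limit, not a number: the limit of > 25000 nM in this assay, at which 1 of the 4 values shown sits. The swap to pyrrolidin-2-yl gives an at least 8.0-fold higher number from compound 1 to compound 4 (0.90 log units; beyond the scatter), so this position, unlike the earlier changes, responds strongly to losing that group.

The compounds shown leave open which part of the leaving group matters. A cyclohexylamino group on this carbonyl carbon would test whether the aromatic ring itself is needed, while keeping the linking nitrogen.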